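The source may report more compounds than this note shows. Statements on the series, on what has been measured and on what is new or still open speak of the compounds shown alone.

Compound 1 `C=C1C[C@]23C[C@@]1(O)CC[C@H]2c1ccc(OS(=O)(=O)c2ccc(C)cc2)c(C)c1[C@@H]3Cn1cc(-c2ccc(Br)cc2)nn1`: > 20000 nM
Compound 2 `C=C1C[C@]23C[C@@]1(O)CC[C@@H]2c1cccc(C)c1[C@@H]3Cn1cc(-c2ccc(Br)cc2)nn1`: > 20000 nM
Compound 3 `Cc1c(O)ccc2c1[C@H](Cn1cc(-c3ccccc3)nn1)[C@@]13CC(=O)[C@@](C)(CC[C@@H]21)C3`: > 20000 nM

In a functional assay on A549 cells (Homo sapiens) for cytotoxicity, read by MTT assay, with a stated time of 4 days (on this read-out lower numbers stand for stronger inhibition and higher numbers for weaker inhibition), compound 2 reaches only > 20000 nM, which is a limit of the assay and not a number. The value of compound 1 is likewise a limit. The value of compound 3 is a limit as well. Thus compound 2 stands where every measured compound stands, at the limit of > 20000 nM in this assay, at which 3 of the 3 values shown sit, so no ordering among them can be read.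

Compound 4 `C=C1C[C@]23C[C@@]1(O)CC[C@@H]2c1cccc(C)c1[C@@H]3Cn1cc(-c2ccc(F)cc2)nn1` differs from compound 2 only by fluoro in place of bromo on an aromatic carbon. Among the measured compounds shown here, no measured pair shows the effect of such a change here. With all three values sitting at the limit, the expected step that the limit leaves unreadable from compound 2 to compound 4 is none beyond the scatter. Compound 4 is therefore expected to give 30000 nM, in the range 10000 nM to 100000 nM, most likely again as a limit.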

Compound 4, half-maximal inhibitory concentration: > 20000 nM
Compound 4 gave a limit, no number; the forecaster's own chance of this, stated with the estimate: 85%; the middle value does not contradict the limit.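

Compound 2 and compound 4 both give a limit and not a number, so no step between them can be read: the limit of > 20000 nM in this assay, at which 4 of the 4 values shown sit 

In this assay the compounds shown leave open how their structures would rank, as none of them gives a number.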